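Methoxy for Trifluoromethyl on the Shared Phenol Core

The compounds below may be only part of what the source reports. "The series", "measured", "known", "first", "only" and "open" are said of these compounds alone.

Compound 3 `O=C(c1cc(Cl)c(O)c(C(F)(F)F)c1)N1CS(=O)(=O)c2ccccc21` gives 2600 nM in an assay on tissue (RPTEC cells) for inhibition of solute carrier family 22 member 12 (Homo sapiens), read by scintillation counting, with stated times of 15 min and 2 h (on this read-out lower numbers stand for stronger inhibition and higher numbers for weaker inhibition), and so carries the lowest of the two numbers shown. Compound 1 `N#Cc1cc(C(=O)N2CCc3ccccc32)cc(Cl)c1O`, which keeps the chloro group but carries a different amide partner, gives 14700 nM in this assay. Compound 2 `N#Cc1cc(C(=O)N2CS(=O)(=O)c3ccccc32)cc(C(F)(F)F)c1O` reaches only the limit of this assay, with > 100000 nM; this limit is noted as the limit of > 100000 nM in this assay, at which 1 of the 3 values shown sits. Among the measured compounds shown here, the one measured step, an at least 38-fold lower number from compound 2 to compound 3 (1.58 log units; beyond the scatter), is large, but it concerns the exchange of cyano for chloro and does not touch the trifluoromethyl group. Compound 4 `COc1cc(C(=O)N2CS(=O)(=O)c3ccccc32)cc(Cl)c1O` differs from compound 3 by methoxy in place of trifluoromethyl on an aromatic carbon. For the measured compounds named here, no measured step bears directly on this exchange, so the expectation rests on compound 3 alone and is held loosely. The step of a 2.3-fold higher number from compound 3 to compound 4 (0.36 log units; beyond the scatter) is expected to be modest, leaning toward a higher number. For compound 4 the estimate in this assay is 6000 nM, with a range from 1500 nM to 25000 nM.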

Compound 4, half-maximal inhibitory concentration: 4300 nM
Estimate against measurement, compound 4: 1.4-fold (0.14 log units) above, and the stated range covers the measured number.
By their numbers in this assay, from the lowest: compounds 3 and 4 (each within the scatter of the next); then compound 1. At a limit, above all of these: compound 2.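

In this assay, putting methoxy in place of trifluoromethyl at this position, ortho to a hydroxy group, gives a 1.7-fold higher number from compound 3 to compound 4 (0.22 log units; within the scatter), so with the chloro group kept, the shared core accepts either group here. The earlier compounds shown here showed only how far the exchange of cyano for chloro can move the number; here, methoxy brings a hydrogen-bond acceptor that trifluoromethyl lacks, and the two numbers stay within the scatter of each other. Nothing given here accounts for this result.

From the compounds shown here alone, whether an amine, a carboxylic acid or a longer chain such as ethoxy would be accepted at this position remains open. Going by these compounds, it is also open whether methoxy and trifluoromethyl would stay as close with cyano in place of chloro or with the amide partner of compound 1.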